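Methoxy for hydroxymethyl on the amine side chain

The source may hold more compounds than are shown below. What is called first, only, known or untested is meant among the compounds shown, and "the series" means these compounds.

Among the compounds with values here, in a functional assay on HT-29 cells (Homo sapiens) for cytotoxicity, read by MTT assay, with a stated time of 48 h (on this read-out higher numbers stand for weaker inhibition and lower numbers for stronger inhibition), compound 3 (`O=C(/C=C(/C=C/c1ccc(O)cc1)NCCCO)/C=C/c1ccc(O)cc1`) gives 58900 nM, the only actual number in this set. Compound 1 (`COc1cc(/C=C/C(=O)/C=C(/C=C/c2ccc(O)c(OC)c2)NCCO)ccc1O`) reads > 100000 nM, which is a limit of the assay. Compound 2 (`COc1cc(/C=C/C2=CC(=O)CC(c3ccc(O)c(OC)c3)N2CCCO)ccc1O`) reads > 100000 nM, also a limit. Compound 4 (`COCCNC(=C\C(=O)/C=C/c1ccc(O)cc1)/C=C/c1ccc(O)cc1`) has the same atoms as compound 3, joined differently: methoxy in place of hydroxymethyl on a saturated chain carbon, two bonds along the chain from an amine nitrogen. Within the data shown here, no measured pair isolates this change, so the estimated step of a 1.1-fold higher number from compound 3 to compound 4 (0.04 log units; within the scatter) is expected to stay within the usual scatter in this assay. For compound 4 the estimated value is 65000 nM, with an expected range of 28000 nM to 150000 nM.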

Compound 4, half-maximal inhibitory concentration: 57400 nM
For compound 4 the middle estimate is 1.1-fold (0.05 log units) above the measured one, and the stated range covers the measured number.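

In this assay, within the data shown here, replacing 3-hydroxypropyl with 2-methoxyethyl gives a 1.0-fold lower number from compound 3 to compound 4 (0.01 log units; within the scatter), the only measured pair that isolates this change. At this place on the chain, the hydrogen-bond donor of hydroxymethyl can therefore be lost without a shift beyond the scatter, at least in this pair. Both compounds still give actual numbers in a set that also reaches the assay limit: the limit of > 100000 nM in this assay, at which 2 of the 4 values shown sit.

On these data alone, whether an amine or a carboxylic acid at the chain end would move the number remains open. So does the effect of a longer chain carrying the methoxy group.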